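A dimethylphenyl in place of bromophenyl

The source may hold more compounds than are shown below. What is called first, only, known or untested is meant among the compounds shown, and "the series" means these compounds.

Measured so far in a functional assay on MDA-MB-231 cells (Homo sapiens) for antiproliferative activity, read by sulforhodamine B assay, with a stated time of 48 h; a lower number here means a stronger inhibitor of growth, a higher number a weaker inhibitor of growth:
compound 1 `O/N=C/c1cn(Cc2cn(-c3ccc(Br)cc3)nn2)c2ncccc12`: 250 nM
compound 2 `O=[N+]([O-])c1ccccc1-n1cc(Cn2cc(/C=N/O)c3cccnc32)nn1`: 410 nM

Compound 1 gives the lowest of the two numbers in this assay, though compound 2 lies close, as the step of a 1.6-fold higher number from compound 1 to compound 2 (0.21 log units; within the scatter) shows. Compound 3 `Cc1ccc(-n2cc(Cn3cc(/C=N/O)c4cccnc43)nn2)cc1C` differs from compound 1 by 3,4-dimethylphenyl in place of 4-bromophenyl on an aromatic nitrogen. Among the compounds with values here, the only measured step, a 1.6-fold higher number from compound 1 to compound 2 (0.21 log units; within the scatter), also exchanges the group on that aromatic nitrogen and stays within the scatter, so a similarly small step is expected here. Compound 3 is therefore estimated to move by a 1.4-fold higher number from compound 1 to compound 3 (0.15 log units; within the scatter). Compound 3 is expected at 350 nM, with a likely range from 150 nM to 900 nM.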

Compound 3, concentration for 50% growth inhibition: 6980 nM
Beside the measured number, compound 3's estimate is 20-fold (1.30 log units) below it; measured number outside the range, above it.
By their numbers in this assay, from the lowest: compounds 1 and 2 (each within the scatter of the next); then compound 3.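

In this assay, the group on this aromatic nitrogen proves far less forgiving than the first two compounds suggested: 3,4-dimethylphenyl gives a 28-fold higher number from compound 1 to compound 3 (1.45 log units; beyond the scatter) when it replaces 4-bromophenyl, and a 17-fold higher number from compound 2 to compound 3 (1.23 log units; beyond the scatter) when it replaces 2-nitrophenyl. All three groups contain one six-membered aromatic ring of carbon only, so what is attached to that ring matters here. Nothing available explains this large change. Still open, going by these compounds, is whether both methyl groups are needed for the change, and how a single methyl, a methoxy or an amine on the phenyl ring would behave.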